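Sulfonyl aryl exchange and rat plasma exposure

A few compounds are considered here, and "the series" means these few. Any claim that something is new, unique, unknown or untested is made for them only; others in the source may bear on it.

Measured compounds:
- compound 2 `CNCc1cn(S(=O)(=O)c2ccco2)c(-c2cccnc2F)c1F`: 26 ng.h/mL
- compound 3 `CNCc1cn(S(=O)(=O)c2cccc(OC)n2)c(-c2cccnc2F)c1F`: 50 ng.h/mL
- compound 1 `CNCc1cc(-c2cccnc2F)n(S(=O)(=O)c2ccccn2)c1`: "not determined" (no result reported)

The set shares one core, and the members differ in the aryl group on the sulfonyl sulfur and in the substituent pattern of the core. In an ADME assay on the whole organism (plasma, Rattus norvegicus, strain Sprague-Dawley) for pharmacokinetics, read by LC-MS, using cassette dosing, at a dose of 0.2 mg/kg by the intravenous route (a higher number here means more compound in the circulation at the dose given, a lower number less compound in the circulation), compound 2 gives 26 ng.h/mL, and compound 3 gives 50 ng.h/mL. In this assay compound 1 gives "not determined" (no result reported), so no number is available for it. Going by the values given here, compound 3 therefore carries the higher of the two available numbers, but the single step of a 1.9-fold higher number from compound 2 to compound 3 (0.28 log units; within the scatter) stays within the scatter, so the two compounds cannot be ordered.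

Compound 4 `CNCc1cn(S(=O)(=O)c2cnccc2C)c(-c2cccnc2F)c1F` is the unmeasured member. It differs from compound 3 only in the aryl group on the sulfonyl sulfur: 4-methylpyridin-3-yl in place of 6-methoxypyridin-2-yl on a sulfonyl sulfur.

Among the compounds with values here, the only measured step that bears on this change is the one from compound 2 to compound 3, which also exchanged the aryl group on the sulfonyl sulfur and gave a 1.9-fold higher number from compound 2 to compound 3 (0.28 log units; within the scatter). With a single such step, itself within the scatter, no movement beyond the scatter is expected in this assay for compound 4. The estimate for compound 4 is 40 ng.h/mL, with a range from 15 ng.h/mL to 110 ng.h/mL, which corresponds to an expected step of a 1.3-fold lower number from compound 3 to compound 4 (0.10 log units; within the scatter).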

Compound 4, area under the concentration-time curve: 41 ng.h/mL
For compound 4 the middle estimate is 1.0-fold (0.01 log units) below the measured one, and the stated range covers the measured number.
By their numbers in this assay, from the lowest: compounds 2, 4 and 3 (each within the scatter of the next).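

In this assay, the exchange of 6-methoxypyridin-2-yl for 4-methylpyridin-3-yl on the sulfonyl sulfur gives a 1.2-fold lower number from compound 3 to compound 4 (0.09 log units; within the scatter) while the exchange of furan-2-yl for the same group gives a 1.6-fold higher number from compound 2 to compound 4 (0.20 log units; within the scatter) and so neither step separates the compounds. Until now this position rested on a single exchange between two aryl groups, whereas three aryl groups on the same core can now be compared, and all the steps among them stay within the scatter, although the entering group brings a methyl substituent and a different place for the ring nitrogen. The measurements at hand offer nothing that would explain these numbers or tie them to any property of the groups.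

The compounds shown leave open whether any group on the sulfonyl sulfur can move this number beyond the scatter, such as a pyridine carrying a carboxylic acid or an amine, or a simple alkyl chain in place of the aryl ring. They also leave the methylaminomethyl side chain of the shared core unexplored, and compound 1 gives "not determined" (no result reported) so it adds no reading here.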